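The source may report more compounds than this note shows. Statements on the series, on what has been measured and on what is new or still open speak of the compounds shown alone.

Inhibition of the growth of HBL2 cells, read after a day, is the single measure here: a functional assay on HBL2 cells (Homo sapiens) for inhibition, read by MTT assay, with a stated time of 24 h; on this read-out higher numbers stand for weaker inhibition of growth and lower numbers for stronger inhibition of growth. Of the compounds shown here, three have been tested. Compound 1 `Nc1nc(N)c2c(n1)NC(=O)C(c1c(Cl)cccc1Cl)C2` reaches only the edge of what the assay can report: in this assay compound 1 gives > 100000 nM, which is a limit and not a number. Compound 3 `CN1C(=O)C(c2c(Cl)cccc2Cl)Cc2c(N)nc(Nc3ccccc3)nc21` likewise stops at the limit, giving > 100000 nM in this assay. Among the compounds with values here, compound 2 `Nc1nc(Nc2ccccc2)nc2[nH]c(=O)c(-c3c(Cl)cccc3Cl)cc12` is the one member of the set that returns a number: in this assay compound 2 gives 8800 nM. Compound 2 thus holds the only number shown, the other two values resting at the limit of > 100000 nM in this assay, at which 2 of the 3 values shown sit.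

Compound 4 `Cn1c(=O)c(-c2c(Cl)cccc2Cl)cc2c(N)nc(Nc3ccccc3)nc21` has not yet been measured. It differs from compound 2 by methyl in place of hydrogen on an aromatic nitrogen. Within the data shown here, no pair of measured compounds differing in one place is available, so the size of such a change cannot be read from a neighbour. The expected step of a 2.3-fold higher number from compound 2 to compound 4 (0.36 log units; beyond the scatter) is a modest loss of potency, toward weaker inhibition of growth, possibly no larger than the usual scatter. Compound 4 is therefore expected to give about 20000 nM, with a likely range from 5000 nM to 100000 nM.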

Compound 4, concentration for 50% growth inhibition: 1700 nM
Compound 4: the middle estimate sits 12-fold (1.07 log units) above what was measured; the whole stated range lies above it.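

Putting a methyl on this aromatic nitrogen of compound 2 does not cost any growth inhibition in this assay and in fact improves it, with a 5.2-fold lower number from compound 2 to compound 4 (0.71 log units; beyond the scatter) as the measured step. Within the data shown here, until now the set offered no pair differing in a single place, so this is the first direct reading of what one small change does on this core, and the lower number means stronger inhibition of growth. It also shows that, for this pair, the hydrogen on that nitrogen is not needed for activity, since compound 4 keeps its activity and gains some with a methyl there, though a single pair speaks only for this position and this change.

The compounds shown offer no measurement that accounts for this gain. As far as these compounds go, what an ethyl group, a longer chain or a chain ending in an amine would do on the same nitrogen stays open, and so does whether a methyl there would have the same effect on a differently substituted core.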